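The source may report more compounds than this note shows. Statements on the series, on what has been measured and on what is new or still open speak of the compounds shown alone.

The compounds here share one core and are compared in a functional assay on HeLa cells (Homo sapiens) for cytotoxicity, read by MTT assay, with a stated time of 2 days; on this read-out lower numbers stand for stronger inhibition and higher numbers for weaker inhibition. Compound 1 `Cc1ccc2nc(-c3ccccc3C(F)(F)F)[nH]c(=O)c2c1` gives 2450 nM in this assay. Among the three measured compounds it stands second highest: compound 2 `Cc1cccc(-c2nc3cc(C)ccc3c(=O)[nH]2)c1` gives 11200 nM, a higher number, while compound 3 `CCN(CC)c1ccc2nc(-c3ccccc3C(F)(F)F)[nH]c(=O)c2c1` gives 100 nM, the lowest of the three. Going by the values given here, the only measured step that changes a single place is a 25-fold lower number from compound 1 to compound 3 (1.39 log units; beyond the scatter), which alters a group on the core and says nothing about the ring that carries the trifluoromethyl.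

Compound 4 `Cc1ccc2nc(-c3ccccc3F)[nH]c(=O)c2c1` differs from compound 1 by fluoro in place of trifluoromethyl on an aromatic carbon. Among the compounds with values here, no measured step bears directly on this change. Compound 2 carries a methyl and no trifluoromethyl on that ring, and its higher number compared with compound 1 shows that altering that ring can weaken the effect, although two things differ there. A somewhat higher number is therefore expected, with wide uncertainty, and the step from compound 1 to compound 4 is estimated as a 2.0-fold higher number from compound 1 to compound 4 (0.31 log units; beyond the scatter). Compound 4 is expected to give about 5000 nM in this assay, between 1500 nM and 16000 nM.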

Compound 4, half-maximal inhibitory concentration: > 50000 nM
Compound 4: a limit, no number (the forecaster's own chance of this, stated with the estimate: 10%); middle value at least 10-fold (1.00 log units) away from the limit.
By their numbers in this assay, from the lowest: compound 3; then compound 1; then compound 2. At a limit, above all of these: compound 4.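

Until now, the only single change shown was on the core, and compound 2 altered two things at once, so the trifluoromethyl place had not been tested alone. With the rest of the structure kept, putting fluoro in place of trifluoromethyl on this aromatic carbon, ortho to a large group, gives an at least 20-fold higher number from compound 1 to compound 4 (1.30 log units; beyond the scatter) in this assay, which shows that activity here depends strongly on which group this place carries. Compound 4 stands at a limit of the assay, not at a number: the limit of > 50000 nM in this assay, at which 1 of the 4 values shown sits.

From the compounds shown here alone, with a single step at this place, what it is about trifluoromethyl that matters stays open. Also open, going by these compounds, are how chloro, methoxy or a nitrile would behave here, and whether diethylamino on the core would lower the number of a compound carrying fluoro.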